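The source may report more compounds than this note shows. Statements on the series, on what has been measured and on what is new or still open speak of the compounds shown alone.

Of the compounds shown here, three have been tested in a functional assay on MCF7 cells (Homo sapiens) for cytotoxicity, read by MTT assay, with a stated time of 72 h, tested at 30 uM; a higher number here means more inhibition of growth at the concentration tested, a lower number less inhibition of growth. Compound 1, `N/C(=N\NC(=S)N1CCCCCC1)c1ccccn1`, and compound 2, `N/C(=N\NC(=S)N1CCOCC1)c1ccccn1`, share a thiosemicarbazide-like backbone attached to an aromatic ring but carry different saturated rings at the far end; the difference between the two cores is not broken down here. In this assay compound 1 gives 76.5% and compound 2 gives 78.1%, two numbers that lie within the usual scatter of each other.

Compound 3, `Cc1cccc(/C(N)=N/NC(=S)N2CCOCC2)n1`, is compound 2 with one change: methyl in place of hydrogen on an aromatic carbon In this assay compound 3 gives 57.8%, and the step of a number 20.3 percentage points lower from compound 2 to compound 3 (beyond the scatter) is beyond the scatter.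

Compound 4, `Cc1cccc(/C(N)=N/NC(=S)N2CCCCCC2)n1`, has not yet been measured. For the measured compounds named here, it is compound 1 with the same kind of change: methyl in place of hydrogen on an aromatic carbon The two changes sit on the same kind of ring at the same kind of place, so the measured step from compound 2 to compound 3 is the only guide available for compound 4. On that basis a step of about the same size is expected, namely a number 19.5 percentage points lower from compound 1 to compound 4 (beyond the scatter), resting on the observation that compound 1 starts at 76.5%, much as compound 2 did. Going by the values given here, for compound 4 the expected result is therefore 57%, with a range from 42% to 70%, since only one earlier example of this change exists.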

Compound 4, percent growth inhibition at one concentration: 38.8%
The estimate for compound 4 lay 18.2 percentage points above the measured number; the measured number lies below the stated range.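

In this assay, putting methyl in place of hydrogen on the aromatic carbon next to the ring nitrogen gives a number 37.7 percentage points lower from compound 1 to compound 4 (beyond the scatter), so on the core of compound 1 this change also goes with less inhibition of growth, as it did on the core of compound 2. For the compounds shown here, the direction of the step therefore carries over from one core to the other, but its size does not: the same change on two cores in this assay, a number 20.3 percentage points lower (beyond the scatter) from compound 2 to compound 3 and a number 37.7 percentage points lower (beyond the scatter) from compound 1 to compound 4, 17.4 percentage points apart, beyond the scatter of two such steps What these two pairs do not show is why the size differs, and with so few examples they give no rule for predicting the step on any further core; they show only that a step measured on one core was not a safe guide to its size on the other.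

The compounds shown leave open whether a different group in the same place, such as ethyl, methoxy or chlorine, would also go with a lower number, and by how much on each core. They also leave open how the methyl step would behave if an open-chain amine stood at the far end of the molecule in place of the saturated ring.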